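The compounds below may be only part of what the source reports. "The series", "measured", "known", "first", "only" and "open" are said of these compounds alone.

Of the compounds shown here, two have so far been measured in an assay on isolated protein for inhibition of AP2-associated protein kinase 1 (Homo sapiens), with a stated time of 3 h, in the presence of a further agent that is not named here; a higher number here means a weaker inhibitor, a lower number a stronger inhibitor. Compound 1 `COC(=O)Nc1cc(-c2cc(Cl)c(OC[C@@](C)(N)CC(C)C)cn2)ccn1` gives 1.1 nM, and compound 2 `CC(C)C[C@](C)(N)COc1cnc(-c2ccnc(Cl)c2)cc1C(F)F` gives 0.8 nM, the lower of the two numbers, though its gap to compound 1 lies within the usual scatter. Compound 3 `CC(C)C[C@](C)(N)COc1cnc(-c2ccnc(Cl)c2)cc1Cl` differs from compound 2 by chloro in place of difluoromethyl on an aromatic carbon. Within the data shown here, no measured pair shows this same change, so the expectation rests on compound 2 alone. The expected step is a 1.3-fold higher number from compound 2 to compound 3 (0.10 log units; within the scatter), a shift not beyond the scatter in either direction. Compound 3 is therefore expected to give 1 nM in this assay, with a range from 0.4 nM to 2.5 nM.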

Compound 3, half-maximal inhibitory concentration: 2.3 nM
For compound 3 the middle estimate is 2.3-fold (0.36 log units) below the measured one; measured number inside the range.
By their numbers in this assay, from the lowest: compounds 2 and 1 (each within the scatter of the next); then compound 3.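

On the aromatic carbon opposite the ring nitrogen, replacing difluoromethyl with chloro gives a 2.9-fold higher number from compound 2 to compound 3 (0.46 log units; beyond the scatter), so this position responds to a change of group by more than the scatter. At a different place in the molecule, chloro in place of (methoxycarbonyl)amino gives a 2.1-fold higher number from compound 1 to compound 3 (0.32 log units; beyond the scatter), a step that is also beyond the scatter. No measurement here explains either step. Still open, on these data alone, is how methyl, trifluoromethyl or a nitrile would compare at the first position. Also open, as far as these compounds go, is how an amine or an amide would compare at the second.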